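From methoxy to hydroxy at the assay limit

This account rests on a few compounds, and the source may have more. Where it says the series, first, only, none or still open, it means among the compounds named here.

In a functional assay on HepG2 cells (Homo sapiens) for inhibition, read by MTT assay, with a stated time of 72 h (a higher number here means a weaker inhibitor, a lower number a stronger inhibitor), compound 1 `COc1cc(O)c(CC=C(C)C)c(O)c1C(=O)/C=C/c1ccc(O)c(O)c1` gives 15200 nM as a measured number. Compound 2 `COc1cc(/C=C/C(=O)c2c(O)cc(O)cc2OC)ccc1O` gives > 50000 nM in this assay and this is a limit of the assay and not a number. Compound 2 therefore stands at the limit, with no exact number of its own.

Compound 3 `COc1cc(O)cc(O)c1C(=O)/C=C/c1ccc(O)c(O)c1` differs from compound 2 in one place (hydrogen in place of methyl on an oxygen on an aromatic ring) with hydrogen in place of methyl on an oxygen on an aromatic ring, which turns a methoxy into a hydroxy. For the measured compounds named here, no measured pair here shows what this swap does, so any forecast is rough. Going by the values given here, compound 1 at 15200 nM is the only measured number so far and serves as a loose guide to how far a gain might go. A modest move toward stronger inhibition is expected, estimated as an at least 1.4-fold lower number from compound 2 to compound 3 (0.15 log units; that floor lies within the scatter) in this assay and it may not clear the usual scatter. For compound 3 the estimate is 35000 nM with an expected range from 15000 nM to 80000 nM and the result could still come back as a limit.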

Compound 3, half-maximal inhibitory concentration: 28700 nM
Beside the measured number, compound 3's estimate is 1.2-fold (0.09 log units) above it; the measured number falls inside the stated range.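

Compound 2 gives > 50000 nM in this assay, and that is a limit of the assay and not a number. Putting hydrogen in place of methyl on this oxygen on an aromatic ring, which turns a methoxy into a hydroxy, gives an at least 1.7-fold lower number from compound 2 to compound 3 (0.24 log units; that floor lies within the scatter); the true step could be larger, but only a floor can be stated because of where compound 2 sits: the limit of > 50000 nM in this assay, at which 1 of the 3 values shown sits. The second comparison is new, with hydrogen in place of 3-methylbut-2-en-1-yl on an aromatic carbon giving a 1.9-fold higher number from compound 1 to compound 3 (0.28 log units; within the scatter), so compound 1 and compound 3 cannot be told apart in this assay, whether or not that chain is present.

From the compounds shown here alone, whether the methoxy to hydroxy swap has a size beyond the scatter stays open, as does what the same swap does when the 3-methylbut-2-en-1-yl group is present. Going by these compounds, how an amine on that aromatic ring in place of the hydroxy, or a longer chain on the aromatic carbon, would read in this assay also stays open.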